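From Pyrimidin-5-yl to (1,3-Thiazol-2-yl)oxy on a Shared Core

The compounds below may be only part of what the source reports. "The series", "measured", "known", "first", "only" and "open" are said of these compounds alone.

Compound 1 `O=C1C(=O)N(Cc2ccc(-c3cncnc3)cc2)c2ccc(OC(F)(F)F)cc21` was examined in a functional assay on CHO cells for positive allosteric modulation of muscarinic acetylcholine receptor M5 (Homo sapiens), read by FLIPR and calcium flux, with a stated time of 1 h (on this read-out lower numbers stand for smaller maximal responses and higher numbers for larger maximal responses), where compound 1 gives 53%. Its neighbour compound 2 `O=C1C(=O)N(Cc2ccc(-c3ccncc3)nc2)c2ccc(OC(F)(F)F)cc21` was run in the same this assay, and compound 2 gives 50%. The two values lie within the usual scatter of each other, so compound 1 cannot be set apart from compound 2 on this read-out; the two measured numbers are, for practical purposes, alike, and compound 1 stands as one of a matched pair.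

Compound 3 `O=C1C(=O)N(Cc2ccc(Oc3nccs3)cc2)c2ccc(OC(F)(F)F)cc21` has not yet been measured. Set against compound 1, its structure differs in a single place: (1,3-thiazol-2-yl)oxy in place of pyrimidin-5-yl on an aromatic carbon. Among the compounds with values here, no step between two measured compounds is available on this read-out, so nothing in the data shows how such an exchange shifts the maximal response. With only the matched pair of compound 1 and compound 2 as background, the step of a number 3 percentage points lower from compound 1 to compound 3 (within the scatter) in this assay is expected to stay within the scatter, in no particular direction. Compound 3 is therefore estimated to give 50% in this assay, with a range from 30% to 70%.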

Compound 3, largest response reached (Emax), in percent of the reference or control that the assay uses: 58%
The estimate for compound 3 lay 8 percentage points below the measured number; low and high end bracket the measured number.
By their numbers in this assay, from the lowest: compounds 2, 1 and 3 (each within the scatter of the next).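

In this assay, the exchange of pyrimidin-5-yl for (1,3-thiazol-2-yl)oxy on an aromatic carbon, para to a large group, appears as a number 5 percentage points higher from compound 1 to compound 3 (within the scatter). Within the data shown here, this is the first step read at this position, and it shows that the maximal response of compound 1 is kept when a six-membered aromatic ring bound directly gives way to a five-membered aromatic ring bound through oxygen, with the heavy-atom count unchanged and sulfur and oxygen entering the substituent. No measurement at hand accounts for this outcome.

The single step changes the ring and adds the oxygen together, so the compounds shown do not separate the two: 1,3-thiazol-2-yl bound directly and pyrimidin-5-yloxy would each be needed to tell them apart. They also leave open whether the same carbon keeps this maximal response when it carries a group of another kind, such as a morpholine amine, a carboxylic acid or a longer alkyl ether chain, since every substituent seen here at this place contains an aromatic ring.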